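This account rests on a few compounds, and the source may have more. Where it says the series, first, only, none or still open, it means among the compounds named here.

Compound 2 `COc1cc(-c2nn(-c3cccc(NC(=O)Nc4cccc(C(F)(F)F)c4)c3)cc2-c2ccncc2)ccc1Cl` stands lowest of the two numbers in a functional assay on NCI-H460 cells (Homo sapiens) for inhibition, read by sulforhodamine B assay, with a stated time of 48 h (on this read-out lower numbers stand for stronger inhibition of growth and higher numbers for weaker inhibition of growth), with compound 2 giving 763 nM; its nearest neighbour, compound 1 `COc1cc(-c2nn(-c3cccc(NC(=O)c4cccc(C(F)(F)F)c4)c3)cc2-c2ccncc2)ccc1Cl`, gives 1450 nM, and a 1.9-fold lower number from compound 1 to compound 2 (0.28 log units; within the scatter) stays within the scatter. Compound 3 `COc1cc(-c2nn(-c3cccc(NC(=O)c4ccc(Cl)c(C(F)(F)F)c4)c3)cc2-c2ccncc2)ccc1Cl` differs from compound 2 in 4-chloro-3-(trifluoromethyl)phenyl in place of (3-(trifluoromethyl)phenyl)amino on a carbonyl carbon. Only a 1.9-fold lower number from compound 1 to compound 2 (0.28 log units; within the scatter) bears on this change, which largely undoes that earlier move while adding chlorine; no step beyond the scatter is therefore expected in this assay, with the number drifting back toward compound 1. Compound 3 is estimated at 1200 nM (range 500 nM to 3000 nM), an expected step of a 1.6-fold higher number from compound 2 to compound 3 (0.20 log units; within the scatter).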

Compound 3, concentration for 50% growth inhibition: 3470 nM
Compound 3: middle estimate off by 2.9-fold (0.46 log units), on the low side; the measured number lies above the stated range.
By their numbers in this assay, from the lowest: compounds 2 and 1 (each within the scatter of the next); then compound 3.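

In this assay, chloro in place of hydrogen on an aromatic carbon gives a 2.4-fold higher number from compound 1 to compound 3 (0.38 log units; beyond the scatter) and so weakens growth inhibition, a change the earlier pair could not show. Replacing (3-(trifluoromethyl)phenyl)amino with 4-chloro-3-(trifluoromethyl)phenyl on the carbonyl carbon gives a 4.5-fold higher number from compound 2 to compound 3 (0.66 log units; beyond the scatter) and also lies beyond the scatter, unlike the step between compound 1 and compound 2. No available evidence accounts for these rises.

Open: whether a fluoro or methoxy group at the chloro position would give a similar step, and whether chloro would cost as much on the (3-(trifluoromethyl)phenyl)amino compound.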